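The source may hold more compounds than are shown below. What is called first, only, known or untested is meant among the compounds shown, and "the series" means these compounds.

Measured so far:
Compound 1, `C=CCc1c(SC)nc2nc(C(=O)c3ccccc3)cn2c1C`, gives 5 mg/kg in a functional assay on the whole organism with Rattus norvegicus as the target; a lower number here means that less compound is needed, a higher number that more compound is needed for the effect.
Compound 2, `CCCc1c(OC)nc2nc(C(=O)c3ccccc3)cn2c1CC`, gives 10 mg/kg in this assay.
Compound 3, `C=CCc1c(OC)nc2nc(C(=O)c3ccccc3)cn2c1C`, gives 5 mg/kg in this assay.

Compound 1 and compound 3 share a core and differ in one group: methylsulfanyl in place of methoxy on an aromatic carbon. This step gave no change at the digits printed from compound 3 to compound 1 (within the scatter). Compound 2 carries a different core; the difference between the two cores is not broken down here, and the two values of compound 2 and compound 3 lie within the scatter of each other.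

Compound 4, `CCCc1c(SC)nc2nc(C(=O)c3ccccc3)cn2c1CC`, is not yet measured. It arises from compound 2 by methylsulfanyl in place of methoxy on an aromatic carbon. Around this place, the group is ortho to a propyl group and meta to an ethyl group, where in compound 1 it is ortho to an allyl group and meta to a methyl group, so it is the same kind of change, not the same change. Since the earlier step gave no change at the digits printed from compound 3 to compound 1 (within the scatter), the step expected in this assay from compound 2 to compound 4 is no change at the digits printed from compound 2 to compound 4 (within the scatter), with the value of compound 2 as its starting point. Compound 4 is therefore estimated at 10 mg/kg, expected to fall between 5 mg/kg and 20 mg/kg.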

Compound 4, minimum effective dose: 10 mg/kg
Beside the measured number, compound 4's estimate shows no gap at the digits printed; measured number inside the range.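

In this assay, putting methylsulfanyl in place of methoxy on the core of compound 2 gave no change at the digits printed from compound 2 to compound 4 (within the scatter). Set beside the same change on the core of compound 1, the two steps agree:
the same change on two cores in this assay, no change at the digits printed (within the scatter) from compound 3 to compound 1 and no change at the digits printed (within the scatter) from compound 2 to compound 4, 1.0-fold (0.00 log units) apart, within the scatter of two such steps

So on these two cores, the change from an oxygen-linked to a sulfur-linked methyl group carried over from one to the other and left the dose needed where it was, within what repeated measurements can tell apart. Among these compounds, this does not show that the change would be just as silent on other cores, since only two pairs stand behind it, and a small real effect could hide inside the scatter.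

Going by these compounds, all four compounds carry either methoxy or methylsulfanyl at this place, so what an amine or a longer alkoxy chain would do there remains open. Also open, on these data alone, is whether the change would behave the same way on a core with a longer chain in place of the propyl group.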